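This account rests on a few compounds, and the source may have more. Where it says the series, first, only, none or still open, it means among the compounds named here.

Of the compounds shown here, three sharing one core have been tested in an assay on isolated protein for inhibition of tyrosine-protein phosphatase non-receptor type 13 (Homo sapiens), read by spectrophotometry; a higher number here means a weaker inhibitor, a lower number a stronger inhibitor. Compound 1 `CCN(CC)C(=O)COc1ccc2cc(C(O)(C(F)(F)F)C(F)(F)F)c(O)cc2c1` carries a diethylamino group on the carbonyl carbon. In this assay compound 1 gives only a limit, > 20000 nM. Compound 2 `O=C(COc1ccc2cc(C(O)(C(F)(F)F)C(F)(F)F)c(O)cc2c1)Nc1nc2ccccc2s1` carries a (1,3-benzothiazol-2-yl)amino group in that place, and in this assay compound 2 gives 9900 nM. Compound 3 `O=C(COc1ccc2cc(C(O)(C(F)(F)F)C(F)(F)F)c(O)cc2c1)Nc1ccccc1` carries an anilino group there. In this assay compound 3 likewise gives only a limit, > 20000 nM. The steps of an at least 2.0-fold lower number from compound 1 to compound 2 (0.30 log units; that floor lies within the scatter) and an at least 2.0-fold higher number from compound 2 to compound 3 (0.30 log units; that floor lies within the scatter) therefore each rest on a limit, and the step that the two limits leave unreadable from compound 1 to compound 3 cannot be sized, since two of the three values sit at the limit of > 20000 nM in this assay, at which 2 of the 3 values shown sit. Compound 4 `CCCNC(=O)COc1ccc2cc(C(O)(C(F)(F)F)C(F)(F)F)c(O)cc2c1` differs from compound 3 by propyl in place of phenyl on an amide-type nitrogen. The nearest measured guide is compound 1, whose open-chain diethylamino group also sits on the carbonyl carbon, and compound 1 reached only its limit. The step from compound 3 to compound 4 is expected to be a step that the limit leaves unreadable from compound 3 to compound 4. Compound 4 is therefore expected to give 30000 nM, within a range of 12000 nM to 90000 nM, most likely as a limit again.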

Compound 4, half-maximal inhibitory concentration: > 20000 nM
Compound 4: no number, only a limit (the forecaster's own chance of this, stated with the estimate: 85%); the middle value is on the limit's open side.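

Propylamino on the carbonyl carbon now joins diethylamino and anilino as a third group that gives no number, so neither a small open chain nor a phenyl ring at this place brings a reading within the range of the assay: the limit of > 20000 nM in this assay, at which 3 of the 4 values shown sit. Compound 2 remains the only compound with a measured number, and propyl in place of its 1,3-benzothiazol-2-yl group gives an at least 2.0-fold higher number from compound 2 to compound 4 (0.30 log units; that floor lies within the scatter). The steps among compounds 1, 3 and 4 cannot be read, so these three groups cannot be put in any order.

Going by these compounds, how far compounds 1, 3 and 4 lie beyond their limits stays unknown. Also open, on these data alone, is whether a longer chain such as octyl, a benzyl group, or a carboxylic acid at the end of the propyl chain would give a number in this assay.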